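The source may report more compounds than this note shows. Statements on the series, on what has been measured and on what is new or still open speak of the compounds shown alone.

Going by the values given here, compound 2 `CCCCCc1ccc(-c2cn(C[C@H](O)[C@H]3OC(=O)C(OCc4ccccc4)=C3OCc3ccccc3)nn2)cc1` is one of two compounds so far tested in a functional assay on HCT-116 cells (Homo sapiens) for antiproliferative activity, read by MTT assay, with a stated time of 72 h; on this read-out lower numbers stand for stronger inhibition and higher numbers for weaker inhibition. In this assay compound 2 gives 13800 nM, the higher of the two numbers, and its nearest neighbour compound 1 `O=C1O[C@H]([C@@H](O)Cn2cc(-c3ccc(Br)cc3)nn2)C(OCc2ccccc2)=C1OCc1ccccc1` gives 9420 nM. Among the compounds with values here, the only measured step, a 1.5-fold higher number from compound 1 to compound 2 (0.17 log units; within the scatter), exchanged one small group on the six-membered aromatic ring for another. Compound 3 `CCCCCCCCCCc1cn(C[C@H](O)[C@H]2OC(=O)C(OCc3ccccc3)=C2OCc2ccccc2)nn1` has not yet been measured; it carries decyl in place of 4-pentylphenyl on an aromatic carbon, so the six-membered aromatic ring itself is gone and a decyl chain stands in its place. Within the data shown here, no measured step removes that ring, so the one step on hand offers only weak guidance. Because a 1.5-fold higher number from compound 1 to compound 2 (0.17 log units; within the scatter) lay within the scatter, a step of no more than similar size is expected here, in no certain direction. The expected step is a 1.1-fold higher number from compound 2 to compound 3 (0.04 log units; within the scatter). Compound 3 is therefore estimated at 15000 nM, with a range from 5000 nM to 45000 nM.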

Compound 3, half-maximal inhibitory concentration: 28800 nM
Estimate against measurement, compound 3: 1.9-fold (0.28 log units) below; measured number inside the range.
By their numbers in this assay, from the lowest: compounds 1 and 2 (each within the scatter of the next); then compound 3.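

Going by these compounds alone, until now only a small group on the six-membered aromatic ring had changed, whereas here the whole 4-pentylphenyl group on the aromatic carbon gives way to decyl, and this exchange produces a 2.1-fold higher number from compound 2 to compound 3 (0.32 log units; beyond the scatter), the first step to pass the scatter. Measured against the 4-bromophenyl group, the same kind of exchange gives a 3.1-fold higher number from compound 1 to compound 3 (0.49 log units; beyond the scatter), so among these three compounds, the two that keep the six-membered aromatic ring both show stronger inhibition than the open chain, though only modestly. Nothing on hand offers an explanation for this difference.

With only decyl as an open chain, the compounds cannot separate the loss of the ring from the length of the chain, and a shorter chain such as hexyl would be needed to tell these apart. Going by these compounds, how a chain ending in an amine or a carboxylic acid would behave at this position also remains open.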